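The compounds below may be only part of what the source reports. "The series", "measured", "known", "first", "only" and "open" are said of these compounds alone.

Compound 1, `Cn1nc2c(=O)n(CC3(O)CCN(Cc4ccc(-c5cccs5)cc4Cl)CC3)cnc2c1-c1ccc(CN)cc1`: 38.6 nM in an assay on isolated protein for inhibition of ubiquitin carboxyl-terminal hydrolase 7 (Homo sapiens), with stated times of 30 min and 2 h; on this read-out lower numbers stand for stronger inhibition and higher numbers for weaker inhibition.
Compound 2, `Cn1nc2c(=O)n(CC3(O)CCN(Cc4ccc(C5=CCCC5)cc4Cl)CC3)cnc2c1-c1ccc(CN)cc1`: 76.9 nM.
Compound 3, `Cn1nc2c(=O)n(CC3(O)CCN(Cc4ccc(-c5ccsc5)cc4Cl)CC3)cnc2c1-c1ccc(CN)cc1`: 59.5 nM.

Compound 3 sits second highest of the three numbers in this assay, and both its neighbours lie within the scatter: a 1.5-fold higher number from compound 1 to compound 3 (0.19 log units; within the scatter) and a 1.3-fold lower number from compound 2 to compound 3 (0.11 log units; within the scatter). Compound 4, `Cn1nc2c(=O)n(CC3(O)CCN(Cc4ccc(-c5ccsc5Cl)cc4Cl)CC3)cnc2c1-c1ccc(CN)cc1`, differs from compound 3 by chloro in place of hydrogen on an aromatic carbon. For the measured compounds named here, none of the measured steps touches this change; they only exchange the ring itself, and each of them, including a 2.0-fold higher number from compound 1 to compound 2 (0.30 log units; within the scatter), stayed within the scatter. Going by the values given here, with no step bearing directly on the added chloro, the account expects compound 4 to move little, giving a 1.0-fold higher number from compound 3 to compound 4 (0.00 log units; within the scatter). The expected value for compound 4 is therefore 60 nM, within a range from 30 nM to 120 nM.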

Compound 4, half-maximal inhibitory concentration: 453 nM
The estimate for compound 4 lay 7.6-fold (0.88 log units) below the measured number; measured number outside the range, above it.
By their numbers in this assay, from the lowest: compounds 1, 3 and 2 (each within the scatter of the next); then compound 4.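

In this assay, chloro on the carbon next to the ring sulfur and next to the ring atom that bears a large group shows a sensitivity that exchanging whole rings did not reveal, with a 7.6-fold higher number from compound 3 to compound 4 (0.88 log units; beyond the scatter) for this single added atom. The 2-chlorothiophen-3-yl group also stands clear of the other rings, with a 5.9-fold higher number from compound 2 to compound 4 (0.77 log units; beyond the scatter) and a 12-fold higher number from compound 1 to compound 4 (1.07 log units; beyond the scatter) as steps beyond the scatter. Nothing available explains this shift. On these data alone, whether it is specific to chloro stays open. Fluoro, methyl or methoxy at this carbon could separate the effect of chloro from that of any added group.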